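Cytotoxicity of three measured compounds and a hexyloxy analogue

A few compounds are considered here, and "the series" means these few. Any claim that something is new, unique, unknown or untested is made for them only; others in the source may bear on it.

Measured so far in an ADME assay on Akata cells (Homo sapiens) for cytotoxicity, with a stated time of 7 days; on this read-out lower numbers stand for higher toxicity in this test and higher numbers for lower toxicity in this test:
Compound 1 `CC(C)CSc1nc(N)nc2c1ncn2/C=C1/CC1(CO)CO` gives > 20000 nM, a limit rather than a number.
Compound 2 `C=CCOc1nc(N)nc2c1ncn2/C=C1/CC1(CO)CO` gives > 20000 nM, also a limit.
Compound 3 `Nc1nc(NCc2ccccc2)c2ncn(/C=C3/CC3(CO)CO)c2n1` gives > 24000 nM, likewise a limit.

Compound 2 therefore stands only on a limit, and the two further values shown are limits as well: two of the three sit at the limit of > 20000 nM in this assay, at which 2 of the 3 values shown sit, one at the limit of > 24000 nM in this assay, at which 1 of the 3 values shown sits. Compound 4 `CCCCCCOc1nc(N)nc2c1ncn2/C=C1/CC1(CO)CO` differs from compound 2 by pentyl in place of vinyl on a saturated chain carbon bound to an oxygen on an aromatic ring. The three measured steps all exchange the group on the aromatic carbon and none touches the chain on the ether oxygen: a step that the two limits leave unreadable from compound 1 to compound 2, a step that the two limits leave unreadable from compound 1 to compound 3, a step that the two limits leave unreadable from compound 2 to compound 3. Each has limits at both ends, so none has a readable size, and none bears directly on a chain extension of this kind. For the measured compounds named here, with no measured step pointing either way, no step beyond the scatter is expected from compound 2 to compound 4, and another limit is the most likely outcome. The expected step in this assay is a step that the limit leaves unreadable from compound 2 to compound 4. Compound 4 is estimated at 30000 nM in this assay, with a range from 10000 nM to 90000 nM.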

Compound 4, half-maximal cytotoxic concentration: > 20000 nM
Compound 4: only a limit was reported; the forecaster's own chance of this, stated with the estimate: 75%; the middle value is on the limit's open side.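

In this assay compound 4 gives > 20000 nM, a limit, so its steps to compound 1, compound 2 and compound 3 cannot be read. The compounds shown leave open whether any of these groups on the aromatic carbon changes the half-maximal cytotoxic concentration at all.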